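Replacing a cyclobutyl with piperidin-1-yl on a carbonyl

This account rests on a few compounds, and the source may have more. Where it says the series, first, only, none or still open, it means among the compounds named here.

Measured compounds:
Compound 1, `O=C1c2sc(C#Cc3ccccc3)nc2CN1C1CC1`: 23 nM
Compound 2, `Fc1cccc(C#Cc2nc3c(s2)CN(C2CCC2)CC3)c1`: 200 nM
Compound 3, `O=C(C1CCC1)N1CCc2nc(C#Cc3ccccc3)sc2C1`: 370 nM

These three compounds were tested in an assay on HEK293 cells for negative allosteric modulation of metabotropic glutamate receptor 5 (Homo sapiens), read by FLIPR, with a stated time of 1 h; a lower number here means a stronger inhibitor, a higher number a weaker inhibitor. Compound 3 shows the highest of the three numbers, yet its number and that of compound 2 lie within the usual scatter of each other, so nothing separates them. Compound 1 gives a number that lies below that of compound 3 by more than the scatter, and compound 1 also carries a different core, so no single change links it to compound 3.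

Compound 4, `O=C(N1CCCCC1)N1CCc2nc(C#Cc3ccccc3)sc2C1`, has not yet been measured. It differs from compound 3 in one place: piperidin-1-yl in place of cyclobutyl on a carbonyl carbon. Among the measured compounds shown here, no pair of measured compounds shows this kind of change, so there is no measured step to lean on. The step of a 1.4-fold higher number from compound 3 to compound 4 (0.13 log units; within the scatter) is expected to be small, toward a higher number, and may well stay inside the scatter. Compound 4 is thus expected to give about 500 nM, within a range from 150 nM to 1500 nM.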

Compound 4, half-maximal inhibitory concentration: > 10000 nM
Compound 4 gave a limit, no number (the forecaster's own chance of this, stated with the estimate: 5%); middle value at least 20-fold (1.30 log units) from the limit.
By their numbers in this assay, from the lowest: compound 1; then compounds 2 and 3 (each within the scatter of the next). At a limit, above all of these: compound 4.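

In this assay, the group on this carbonyl carbon, whose other neighbour is an amide-type nitrogen in a ring, turns out to matter greatly: piperidin-1-yl in place of cyclobutyl gives an at least 27-fold higher number from compound 3 to compound 4 (1.43 log units; beyond the scatter). From the compounds shown here alone, compound 4 gives > 10000 nM, which is a limit of the assay and not a number, so the full size of the step stays unknown. Among the compounds shown, this is the only single change that can be read, and it takes the series to the limit of the assay: the limit of > 10000 nM in this assay, at which 1 of the 4 values shown sits.

The step changes two things together, a four-membered carbon ring becoming a six-membered ring and a nitrogen entering at the point of attachment, and the data cannot separate them. Cyclohexyl on the same carbonyl carbon would keep the six-membered ring without that nitrogen, while pyrrolidin-1-yl would keep the nitrogen in a smaller ring, and how either would read remains open.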